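This account rests on a few compounds, and the source may have more. Where it says the series, first, only, none or still open, it means among the compounds named here.

Measured so far:
compound 1, `Cc1ccc(Nc2cc(C)nc(SCc3nc4ccccc4[nH]3)n2)cc1`, 56000 nM
compound 2, `COc1ccccc1Nc1cc(C)nc(SCc2nc3ccccc3[nH]2)n1`, 70800 nM

Both numbers come from a functional assay on PC-3 cells (Homo sapiens) for cytotoxicity, read by MTT assay, with a stated time of 72 h; a higher number here means a weaker inhibitor, a lower number a stronger inhibitor. Compound 2 has the highest of the two numbers, and its nearest neighbour is compound 1: the step of a 1.3-fold higher number from compound 1 to compound 2 (0.10 log units; within the scatter) lies within the scatter, so the two compounds cannot be ordered.

Compound 3, `Cc1cc(Nc2ccc(F)cc2)nc(SCc2nc3ccccc3[nH]2)n1`, is not yet measured. It differs from compound 2 in one place: 4-fluorophenyl in place of 2-methoxyphenyl on a nitrogen on an aromatic ring. For the measured compounds named here, the only measured step that bears on this place is the one from compound 1 to compound 2, which also swapped the ring on that nitrogen and gave a 1.3-fold higher number from compound 1 to compound 2 (0.10 log units; within the scatter). On that evidence a further swap of the same ring is expected to give a step of no more than the scatter in this assay, with no clear direction, so a 1.2-fold lower number from compound 2 to compound 3 (0.07 log units; within the scatter) is the expected step. Compound 3 is therefore estimated at 60000 nM, with a range from 25000 nM to 150000 nM.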

Compound 3, half-maximal inhibitory concentration: 56200 nM
Compound 3: middle estimate off by 1.1-fold (0.03 log units), on the high side; measured number inside the range.
By their numbers in this assay, from the lowest: compounds 1, 3 and 2 (each within the scatter of the next).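

In this assay, a further ring on this nitrogen again leaves the number within the scatter: 4-fluorophenyl in place of 2-methoxyphenyl gives a 1.3-fold lower number from compound 2 to compound 3 (0.10 log units; within the scatter) and no order can be drawn from it. The comparison with the 4-methylphenyl ring, fluoro in place of methyl on an aromatic carbon, gives a 1.0-fold higher number from compound 1 to compound 3 (0.00 log units; within the scatter) and is also within the scatter, so compound 1, compound 2 and compound 3 cannot be ordered, and across these three rings the position shows no measurable change. Nothing measured here accounts for this similarity.

From the compounds shown here alone, whether a carboxylic acid on this ring, or a morpholine in place of the ring, would move the number beyond the scatter stays open. Going by these compounds, the rest of the core is the same in all three compounds, so what an amine or a longer chain would do there also stays open.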